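A few compounds are considered here, and "the series" means these few. Any claim that something is new, unique, unknown or untested is made for them only; others in the source may bear on it.

In an in vitro assay on HEK-293T cells for antagonist activity at transient receptor potential cation channel subfamily V member 1 (Rattus norvegicus), read by fluorescence and calcium flux, with a stated time of 30 min (a higher number here means a weaker inhibitor, a lower number a stronger inhibitor), three compounds built on one shared core have been measured. Compound 1 `CCCCCCCC(=O)Nc1nnc(-c2ccc(O)c(OC)c2)s1` gives 0.15 nM, and compound 2 `CCCCCCCCC(=O)Nc1nnc(-c2cc(I)c(O)c(OC)c2)s1` gives 0.34 nM. Compound 3 `CCCCCC(=O)Nc1nnc(-c2ccc(O)c(OC)c2)s1` gives 2.61 nM, the highest of the three numbers, and its distance from each of the other two lies beyond the scatter, so it is the weakest inhibitor of the three.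

Within the data shown here, the only measured change at the same place is a 17-fold higher number from compound 1 to compound 3 (1.24 log units; beyond the scatter), a large move toward weaker inhibition when part of the chain is taken away. Compound 4 `CCCCCCCCC(=O)Nc1nnc(-c2ccc(O)c(OC)c2)s1` differs from compound 3 by propyl in place of hydrogen on a saturated chain carbon, five bonds along the chain from a carbonyl carbon, which puts back more chain than that step removed. The step is therefore expected to run the other way, toward a lower number, and its size is expected to be at least comparable, giving an expected 13-fold lower number from compound 3 to compound 4 (1.12 log units; beyond the scatter). Compound 4 carries the same chain as compound 2, whose value of 0.34 nM is also low. Compound 4 is estimated at 0.2 nM, with a range from 0.07 nM to 0.7 nM.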

Compound 4, half-maximal inhibitory concentration: 0.18 nM
The estimate for compound 4 lay 1.1-fold (0.05 log units) above the measured number; the range from low to high includes it.
By their numbers in this assay, from the lowest: compounds 1, 4 and 2 (each within the scatter of the next, the first and the last beyond it); then compound 3.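

In this assay the chain can now be read in the lengthening direction: propyl in place of hydrogen on a saturated chain carbon, five bonds along the chain from a carbonyl carbon, gives a 15-fold lower number from compound 3 to compound 4 (1.16 log units; beyond the scatter) and so a large move toward stronger inhibition. The further methyl that separates the chains of compound 1 and compound 4 gives a 1.2-fold higher number from compound 1 to compound 4 (0.08 log units; within the scatter) and stays within the scatter, so these two compounds cannot be told apart. Hydrogen in place of iodo on an aromatic carbon gives a 1.9-fold lower number from compound 2 to compound 4 (0.28 log units; within the scatter) and is also within the scatter, so on this chain the iodo makes no readable difference.

As far as these compounds go, whether a longer chain than that of compound 4, or an amine in place of the propyl, would hold this low range remains open. Nothing available explains why the chain change acts as it does.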